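Three Ureas at the Assay Limit and a Fourth to Test

The source may hold more compounds than are shown below. What is called first, only, known or untested is meant among the compounds shown, and "the series" means these compounds.

Three ureas on a shared core have been tested in an ADME assay on Raji cells (Homo sapiens) for cytotoxicity, with a stated time of 72 h; a lower number here means that less compound is needed, a higher number that more compound is needed for the effect. Compound 1 `Cc1cc(NC(=O)Nc2ccc([N+](=O)[O-])c(C(F)(F)F)c2)c2ccccc2n1` returns only a limit, > 25000 nM. Compound 2 `Cc1cc(NC(=O)Nc2cc(F)ccc2F)c2ccccc2n1` likewise gives a limit of > 25000 nM. Compound 3 `Cc1cc(NC(=O)Nc2ncccc2C)c2ccccc2n1` also stops at a limit, > 25000 nM, so that compound 3 stands at the limit of > 25000 nM in this assay, at which 3 of the 3 values shown sit, and no number separates it from its two companions. Compound 4 `Cc1cc(NC(=O)Nc2ccc(O)cc2)c2ccccc2n1` differs from compound 3 in one place: 4-hydroxyphenyl in place of 3-methylpyridin-2-yl on an amide-type nitrogen. Among the compounds with values here, no measured pair shows the effect of such a change, so no step in this assay is expected beyond the scatter, and the step of a number no higher from compound 3 to compound 4 (the limit leaves the size open) is estimated to be flat. Compound 4 is therefore expected to give 25000 nM, within 10000 nM to 60000 nM, most likely again as a limit.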

Compound 4, half-maximal effective concentration: > 25000 nM
Compound 4: no number, only a limit (the forecaster's own chance of this, stated with the estimate: 80%); the middle value sits exactly at the limit.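

Compound 3 and compound 4 both end at a limit in this assay, so no step between them can be read: the limit of > 25000 nM in this assay, at which 4 of the 4 values shown sit.

The compounds shown leave open how much of any of them the effect would need, and whether 4-hydroxyphenyl and 3-methylpyridin-2-yl differ here at all.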